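The source may hold more compounds than are shown below. What is called first, only, known or untested is meant among the compounds shown, and "the series" means these compounds.

Measured so far, in an ADME assay on cells (Fibroblast, Homo sapiens) for cytotoxicity, with a stated time of 48 h; a higher number here means a weaker inhibitor, a lower number a stronger inhibitor:
- compound 1, `O=[N+]([O-])c1ccc(CN2CCC(n3cc(CC(OCc4cc(-c5ccc(Br)cc5)no4)c4ccc(Br)cc4)nn3)CC2)cc1`, a limit of > 25000 nM
- compound 2, `COc1ccc(-c2cc(COC(Cc3cn(C4CCN(Cc5ccc([N+](=O)[O-])cc5)CC4)nn3)c3ccc(Br)cc3)on2)cc1`, a limit of > 25000 nM
- compound 3, `N#Cc1ccc(-c2cc(COC(Cc3cn(C4CCN(Cc5ccc([N+](=O)[O-])cc5)CC4)nn3)c3ccc(Br)cc3)on2)cc1`, a limit of > 25000 nM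

Compound 3 stands at a limit in this assay, and the value it gives, > 25000 nM, is a limit and not a number. Compound 1 also sits at a limit with > 25000 nM. Compound 2 likewise sits at a limit with > 25000 nM. All three of the values seen so far sit at the same place: the limit of > 25000 nM in this assay, at which 3 of the 3 values shown sit. The measured steps among them are therefore all unreadable: a step that the two limits leave unreadable from compound 1 to compound 2, a step that the two limits leave unreadable from compound 1 to compound 3 and a step that the two limits leave unreadable from compound 2 to compound 3 give no size.

Compound 4, `O=[N+]([O-])c1ccc(CN2CCC(n3cc(CC(OCc4cc(-c5cccc(Br)c5)no4)c4ccc(Br)cc4)nn3)CC2)cc1`, differs from compound 3 by 3-bromophenyl in place of 4-cyanophenyl on an aromatic carbon. Among the compounds with values here, the only steps that bear on this change, the exchanges on the same aromatic carbon from compound 1 to compound 2 and from compound 1 to compound 3, show no readable size, so no step beyond the scatter is expected in this assay: a step that the limit leaves unreadable from compound 3 to compound 4. Compound 4 is expected to give about 30000 nM, with a range from 12000 nM to 80000 nM, most likely reported again as a limit.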

Compound 4, half-maximal inhibitory concentration: > 25000 nM
Compound 4 was reported as a limit; the forecaster's own chance of this, stated with the estimate: 85%; the middle value does not contradict the limit.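

Compound 4 gives > 25000 nM in this assay and this value is a limit. Within the data shown here, no step from compound 1, compound 2 or compound 3 to compound 4 can be read: the limit of > 25000 nM in this assay, at which 4 of the 4 values shown sit. In this assay the compounds shown leave open whether any change on the shared core gives a readable number.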